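Aryl sulfonate for isopropyl sulfonate: expected cytotoxicity

The source may hold more compounds than are shown below. What is called first, only, known or untested is meant among the compounds shown, and "the series" means these compounds.

Three members of the series have been read in an ADME assay on Vero cells (Chlorocebus sabaeus) for cytotoxicity, read by MTT assay, with a stated time of 48 h; on this read-out lower numbers stand for stronger inhibition and higher numbers for weaker inhibition. Compound 1 `CC(C)S(=O)(=O)OC1CCC(CN2CCN(c3cc(=O)c4cc(C(F)(F)F)cc([N+](=O)[O-])c4s3)CC2)CC1` carries an (isopropylsulfonyl)oxy group on a saturated ring carbon. In this assay compound 1 gives only a limit, > 64 ug/mL. Compound 2 `O=c1cc(N2CCN(CC3CCC(NS(=O)(=O)c4ccccc4)CC3)CC2)sc2c([N+](=O)[O-])cc(C(F)(F)F)cc12` bears (phenylsulfonyl)amino in its place, and in this assay compound 2 likewise gives a limit, > 64 ug/mL. Compound 3 `O=C(NC1CCC(CN2CCN(c3cc(=O)c4cc(C(F)(F)F)cc([N+](=O)[O-])c4s3)CC2)CC1)c1ccccc1`, with benzamido at that carbon, gives 44.3 ug/mL in this assay. The step that the two limits leave unreadable from compound 1 to compound 2; the step of an at least 1.4-fold lower number from compound 1 to compound 3 (0.15 log units; that floor lies within the scatter); the step of an at least 1.4-fold lower number from compound 2 to compound 3 (0.15 log units; that floor lies within the scatter). Two of the three values sit at the limit of > 64 ug/mL in this assay, at which 2 of the 3 values shown sit, so compound 1 stands at that limit with no number of its own to compare.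

Compound 4 `O=c1cc(N2CCN(CC3CCC(OS(=O)(=O)c4ccc5c(c4)CCO5)CC3)CC2)sc2c([N+](=O)[O-])cc(C(F)(F)F)cc12` differs from compound 1 (a group of 9 heavy atoms (8 carbon, 1 oxygen; one five-membered non-aromatic ring with 1 hetero atom, one six-membered aromatic ring of carbon only) in place of a group of 3 heavy atoms (3 carbon; no ring), on a sulfonyl sulfur). Among the measured compounds shown here, no measured step alters the group on the sulfonyl sulfur itself. The nearest steps are those from compound 1 to compound 2 and to compound 3, where a ring-bearing group enters and the read-out stays at the limit or comes out close to it. A step beyond the scatter in this assay is therefore not expected. The estimate for compound 4 is 60 ug/mL, from 25 ug/mL to 130 ug/mL. This corresponds to an expected step of an at least 1.0-fold lower number from compound 1 to compound 4 (0.02 log units; that floor lies within the scatter), with a fair chance that only a limit is again reported.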

Compound 4, half-maximal inhibitory concentration: > 64 ug/mL
Compound 4 ended at the assay's limit (the forecaster's own chance of this, stated with the estimate: 55%); middle value at least 1.0-fold (0.02 log units) away from the limit.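

In this assay compound 4 gives > 64 ug/mL, a limit and not a number. Compound 1 also gives only a limit, so no step can be read between compound 1 and compound 4: the limit of > 64 ug/mL in this assay, at which 3 of the 4 values shown sit.

The compounds shown leave open whether changing the group on the sulfonyl sulfur moves the read-out in this assay at all.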